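Cytotoxicity of Two Bis-Fluorobenzylidene Sulfonamide Pairs

A few compounds are considered here, and "the series" means these few. Any claim that something is new, unique, unknown or untested is made for them only; others in the source may bear on it.

compound 1, `N#Cc1ccc(S(=O)(=O)N2C/C(=C\c3cccc(F)c3)C(=O)/C(=C/c3cccc(F)c3)C2)cc1`: 15500 nM
compound 2, `CC(=O)Nc1ccc(S(=O)(=O)N2C/C(=C\c3cccc(F)c3)C(=O)/C(=C/c3cccc(F)c3)C2)cc1`: 17500 nM
compound 3, `N#Cc1ccc(S(=O)(=O)N2C/C(=C\c3ccc(F)cc3)C(=O)/C(=C/c3ccc(F)cc3)C2)cc1`: 14700 nM

In an ADME assay on L02 cells (Homo sapiens) for cytotoxicity, read by MTT assay, with a stated time of 24 h (on this read-out lower numbers stand for stronger inhibition and higher numbers for weaker inhibition), compound 1 gives 15500 nM, compound 2 gives 17500 nM and compound 3 gives 14700 nM. Compound 2 differs from compound 1 by acetamido in place of cyano on an aromatic carbon, and the step is a 1.1-fold higher number from compound 1 to compound 2 (0.05 log units; within the scatter). Compound 4, `CC(=O)Nc1ccc(S(=O)(=O)N2C/C(=C\c3ccc(F)cc3)C(=O)/C(=C/c3ccc(F)cc3)C2)cc1`, differs from compound 3 by acetamido in place of cyano on an aromatic carbon, the same change at the same place. The difference between the core of compound 1 and the core of compound 3 is not broken down here; their two values lie within the scatter of each other. Resting on the step of a 1.1-fold higher number from compound 1 to compound 2 (0.05 log units; within the scatter), compound 4 is expected to show a step of a 1.1-fold higher number from compound 3 to compound 4 (0.05 log units; within the scatter). Compound 4 is therefore estimated at 16500 nM, with a range from 9000 nM to 30000 nM.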

Compound 4, half-maximal inhibitory concentration: 19400 nM
Estimate against measurement, compound 4: 1.2-fold (0.07 log units) below; measured number inside the range.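

In this assay the change from 4-cyanophenyl to 4-acetamidophenyl gives a 1.3-fold higher number from compound 3 to compound 4 (0.12 log units; within the scatter) on the second core. Set beside the first core, the two steps agree: the same change on two cores in this assay, a 1.1-fold higher number (0.05 log units; within the scatter) from compound 1 to compound 2 and a 1.3-fold higher number (0.12 log units; within the scatter) from compound 3 to compound 4, 1.2-fold (0.07 log units) apart, within the scatter of two such steps. This shows that the change carries across these two cores without any gap beyond the scatter, but since each step lies within the scatter, it does not show that the change has a real effect on the number, or that it would carry to any other core.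

The compounds shown hold only cyano and acetamido at this place. Going by these compounds, whether an amine, a carboxylic acid or a longer acyl chain there would move the number beyond the scatter remains open.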